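Series notes: a cyclic amide replaces the acyclic group

A few compounds are considered here, and "the series" means these few. Any claim that something is new, unique, unknown or untested is made for them only; others in the source may bear on it.

Measured so far in a functional assay with Oryctolagus cuniculus as the target; on this read-out lower numbers stand for stronger inhibition and higher numbers for weaker inhibition:
compound 1 `CC/N=C(/N)Nc1nc(-c2ccc(OC)cc2)c(-c2ccc(OC)cc2)s1` gives > 100 nM, a limit of the assay.
compound 2 `COc1ccc(-c2nc(/N=C(\N)NC(C)C)sc2-c2ccc(OC)cc2)cc1` gives > 100 nM, a limit of the assay.
compound 3 `COc1ccc(-c2nc(C(=O)N3CCOCC3)sc2-c2ccc(OC)cc2)cc1` gives < 10 nM, a limit of the assay.

Compound 1 stands at the limit of > 100 nM in this assay, at which 2 of the 3 values shown sit, so only a limit is known for it. Compound 4 `COc1ccc(-c2nc(C(=O)N3CCCCC3)sc2-c2ccc(OC)cc2)cc1` differs from compound 1 by a group of 8 heavy atoms (6 carbon, 1 nitrogen, 1 oxygen; one six-membered non-aromatic ring with 1 hetero atom) in place of a group of 6 heavy atoms (3 carbon, 3 nitrogen; no ring), on an aromatic carbon. The closest measured step is an at least 10-fold lower number from compound 1 to compound 3 (1.00 log units; beyond the scatter), which brought compound 3 to the limit of < 10 nM in this assay, at which 1 of the 3 values shown sits. The parallel step an at least 10-fold lower number from compound 2 to compound 3 (1.00 log units; beyond the scatter) reads alike, whereas a step that the two limits leave unreadable from compound 1 to compound 2. Both readable steps replace the acyclic group with a carbonyl bearing a six-membered non-aromatic ring, as compound 4 does. A step in the same direction, at least as large, is therefore expected: an at least 12-fold lower number from compound 1 to compound 4 (1.09 log units; beyond the scatter). Compound 4 is estimated at 8 nM, between 3 nM and 30 nM, and the assay may again report only a limit.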

Compound 4, half-maximal inhibitory concentration: > 1000 nM
Compound 4: a limit, no number (the forecaster's own chance of this, stated with the estimate: 50%); middle value at least 120-fold (2.09 log units) away from the limit.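

In this assay, a carbonyl bearing a six-membered non-aromatic ring is not enough at this position: piperidin-1-yl in place of morpholin-4-yl gives an at least 100-fold higher number from compound 3 to compound 4 (2.00 log units; beyond the scatter). The earlier compounds shown here compared only the acyclic groups with morpholin-4-yl, whereas here the result turns on the ring atoms alone. The steps from compound 1 and compound 2 to compound 4 cannot be read.

As far as these compounds go, whether piperazin-1-yl or an open-chain dimethylamino group on the carbonyl would track compound 3 or compound 4 stays open. From the compounds shown here alone, both of those compounds are known only as limits, so the full size of the step also stays open.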